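Benzyloxycarbonyl for methyl on the chloro core

The source may report more compounds than this note shows. Statements on the series, on what has been measured and on what is new or still open speak of the compounds shown alone.

The series rests on a shared core carrying a phenyl-substituted pyrazole. Compound 1 `Cc1ccc2[nH]c(-c3cn(-c4ccccc4)nc3-c3ccc(F)cc3)nc2c1` gives 1120 nM in a functional assay on MCF7 cells (Homo sapiens) for antiproliferative activity, read by MTT assay, with a stated time of 48 h; a higher number here means a weaker inhibitor, a lower number a stronger inhibitor. Compound 2 `O=C(OCc1ccccc1)c1ccc2[nH]c(-c3cn(-c4ccccc4)nc3-c3ccc(F)cc3)nc2c1` gives 9240 nM in this assay. Compound 3 `Cc1ccc2[nH]c(-c3cn(-c4ccccc4)nc3-c3ccc(Cl)cc3)nc2c1` gives 8230 nM in this assay. Compound 4 `O=C(OCc1ccccc1)c1ccc2[nH]c(-c3cn(-c4ccccc4)nc3-c3ccc(Cl)cc3)nc2c1` is not yet measured.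

The change from compound 1 to compound 2 is benzyloxycarbonyl in place of methyl on an aromatic carbon; it made a step of an 8.3-fold higher number from compound 1 to compound 2 (0.92 log units; beyond the scatter). The cores of compound 1 and compound 3 differ by chloro in place of fluoro on an aromatic carbon, a step of a 7.3-fold higher number from compound 1 to compound 3 (0.87 log units; beyond the scatter). Compound 3 and compound 2 show numbers within the scatter of each other.

The change from compound 3 to compound 4 is benzyloxycarbonyl in place of methyl on an aromatic carbon. Among the compounds shown the same change occurs two times in all, once measured and once pending. Among the measured compounds shown here, the step from compound 3 to compound 4 is expected at a 5.5-fold higher number from compound 3 to compound 4 (0.74 log units; beyond the scatter), beside the earlier 8.3-fold higher number from compound 1 to compound 2 (0.92 log units; beyond the scatter), since compound 1 to compound 2 is the only measured instance and compound 3 starts from 8230 nM. Compound 4 is therefore estimated at 45000 nM in this assay, expected between 12000 nM and 150000 nM.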

Compound 4, half-maximal inhibitory concentration: 13900 nM
Compound 4: the middle estimate sits 3.2-fold (0.51 log units) above what was measured; low and high end bracket the measured number.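

In this assay, benzyloxycarbonyl in place of methyl on the chloro core gives a 1.7-fold higher number from compound 3 to compound 4 (0.23 log units; within the scatter), so the step seen on the fluoro core does not carry over in size: the same change on two cores in this assay, an 8.3-fold higher number (0.92 log units; beyond the scatter) from compound 1 to compound 2 and a 1.7-fold higher number (0.23 log units; within the scatter) from compound 3 to compound 4, 4.9-fold (0.69 log units) apart, beyond the scatter of two such steps

Chloro in place of fluoro on the benzyloxycarbonyl core gives a 1.5-fold higher number from compound 2 to compound 4 (0.18 log units; within the scatter), and this step also falls short of its counterpart on the methyl core: the same change on two cores in this assay, a 7.3-fold higher number (0.87 log units; beyond the scatter) from compound 1 to compound 3 and a 1.5-fold higher number (0.18 log units; within the scatter) from compound 2 to compound 4, 4.9-fold (0.69 log units) apart, beyond the scatter of two such steps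

Compound 1 alone stands apart, while compound 2, compound 3 and compound 4 lie within the scatter of one another, so the two changes do not add here, but this single set of four compounds shows neither why nor whether the same holds on any other core.

Still open, on these data alone, is whether a carboxylic acid or an amine in place of benzyloxycarbonyl on the shared core would follow the same course. Equally open, as far as these compounds go, is whether bromo or methoxy in place of the halogen would keep the methyl core as far apart as compound 1 stands.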